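Dropping the Pyrrolidin-1-yl Group and Cell Tolerance

This account rests on a few compounds, and the source may have more. Where it says the series, first, only, none or still open, it means among the compounds named here.

Compound 1 `Cn1c(-c2ccc(NC(=O)CN3CCCC3)cc2)nc2cc(C(F)(F)F)ccc21` gives 27000 nM in an ADME assay on BHK cells (Mesocricetus auratus) for cytotoxicity, read by MTT assay, with a stated time of 96 h; a lower number here means that less compound is tolerated, a higher number that more compound is tolerated.
Compound 2 `CC(=O)Nc1ccc(-c2nc3cc(C(F)(F)F)ccc3n2C)cc1` gives > 100000 nM in this assay, which is a limit of the assay and not a number.
Compound 3 `O=C(CN1CCCC1)Nc1ccc(-c2nc3ccccc3[nH]2)cc1` gives 55000 nM in this assay.

Compound 1 and compound 2 share a core and differ in one place: hydrogen in place of pyrrolidin-1-yl on a saturated chain carbon bound to a carbonyl carbon. This single change made a step of an at least 3.7-fold higher number from compound 1 to compound 2 (0.56 log units; beyond the scatter), and the step can only be given as a bound because of the limit of > 100000 nM in this assay, at which 1 of the 3 values shown sits. Compound 3 carries the same pyrrolidin-1-yl group as compound 1 but on another core; the difference between the two cores is not broken down here. Of the two values that are numbers, compound 3 gives the higher one, and its gap to compound 1 lies beyond the scatter.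

Compound 4 `CC(=O)Nc1ccc(-c2nc3ccccc3[nH]2)cc1` has not yet been measured in this assay. It stands to compound 3 as compound 2 stands to compound 1: hydrogen in place of pyrrolidin-1-yl on a saturated chain carbon bound to a carbonyl carbon, the same change at the same place. A step of a 2.7-fold higher number from compound 3 to compound 4 (0.44 log units; beyond the scatter) is expected, since the same change earlier gave an at least 3.7-fold higher number from compound 1 to compound 2 (0.56 log units; beyond the scatter). Compound 3 already starts from 55000 nM, the higher of the two numbers. Compound 4 is therefore expected to give about 150000 nM, quite possibly reported only as a limit, within a range from 55000 nM to 400000 nM.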

Compound 4, half-maximal cytotoxic concentration: > 100000 nM
Compound 4 ended at the assay's limit (the forecaster's own chance of this, stated with the estimate: 65%); the middle value lies beyond the limit too.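

In this assay, putting hydrogen in place of pyrrolidin-1-yl on the core of compound 3 gave an at least 1.8-fold higher number from compound 3 to compound 4 (0.25 log units; that floor lies within the scatter), so this floor alone does not establish a change beyond the usual scatter on this core. The result fits the earlier step, since neither core gives a lower number after the change, but it does not show that the change has the same size on both cores, and the two steps side by side read: the same change on two cores in this assay, an at least 3.7-fold higher number (0.56 log units; beyond the scatter) from compound 1 to compound 2 and an at least 1.8-fold higher number (0.25 log units; that floor lies within the scatter) from compound 3 to compound 4; the limit leaves it open whether they differ. From the compounds shown here alone, the true size of the step on either core stays unknown, and no larger step can be read from these data, because the measurements stop at a ceiling: the limit of > 100000 nM in this assay, at which 2 of the 4 values shown sit.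

The compounds shown leave open whether the lower tolerance of compounds 1 and 3 belongs to pyrrolidin-1-yl itself or would also appear with another amine, such as dimethylamino or piperidin-1-yl, with a carboxylic acid, or with a longer chain between the amine and the carbonyl. They also leave open how each part of the difference between the two cores contributes, since compounds 1 and 3 differ in more than one place.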